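The source may hold more compounds than are shown below. What is called first, only, known or untested is meant among the compounds shown, and "the series" means these compounds.

Compounds measured in an ADME assay on microsomes from liver (Rattus norvegicus) for metabolic stability; on this read-out lower numbers stand for a shorter-lived compound and higher numbers for a longer-lived compound:
compound 1 `CCC(CC)C(/C=C1\OC(=O)NC1=O)c1ccc(-c2ccc3cccc(F)c3c2)[nH]c1=O`: > 3 h
compound 2 `CC(C)C(c1ccc(-c2ccc3cccc(F)c3c2)[nH]c1=O)C1C(=O)NC(=O)N1C`: 0.263 h

The result for compound 1 is a limit of the assay rather than a number; (the limit of > 3 h in this assay, at which 1 of the 2 values shown sits). Compound 2 gives the only plain number shown, 0.263 h. Compound 3 `CC(C)C(/C=C1\SC(=O)NC1=O)c1ccc(-c2ccc3cccc(F)c3c2)[nH]c1=O` has not been measured yet; it differs from compound 2 by a group of 8 heavy atoms (4 carbon, 1 nitrogen, 2 oxygen, 1 sulfur; one five-membered non-aromatic ring with 2 hetero atoms) in place of a group of 8 heavy atoms (4 carbon, 2 nitrogen, 2 oxygen; one five-membered non-aromatic ring with 2 hetero atoms), on a saturated chain carbon bound to an aromatic carbon and a saturated chain carbon. For the measured compounds named here, no step between measured compounds is available, so what follows rests on the two values alone. The step of a 5.7-fold higher number from compound 2 to compound 3 (0.76 log units; beyond the scatter) is expected to be an increase beyond the usual scatter. Compound 3 is estimated at 1.5 h, with a likely range from 0.5 h to 3.5 h.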

Compound 3, half-life: 2.62 h
Compound 3: middle estimate off by 1.7-fold (0.24 log units), on the low side, within the range that was stated.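

Swapping the 3-methyl-2,5-dioxoimidazolidin-4-yl group on this saturated chain carbon for the sulfur-containing ring changes the result in this assay markedly, giving a 10-fold higher number from compound 2 to compound 3 (1.00 log units; beyond the scatter). Both groups have the same heavy-atom count and a five-membered non-aromatic ring with 2 hetero atoms, so those shared counts alone do not fix the half-life. Compound 3 still gives a plain number, so this step can be read in full: the limit of > 3 h in this assay, at which 1 of the 3 values shown sits.

Sulfur and the extra double bond enter together, so their separate contributions remain open. Going by these compounds, how an amine or a carboxylic acid at this place would behave also remains open.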